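The source may report more compounds than this note shows. Statements on the series, on what has been measured and on what is new or still open speak of the compounds shown alone.

In a functional assay on MCF7 cells (Homo sapiens) for cytotoxicity, read by CellTiter-Glo, with a stated time of 5 days (on this read-out higher numbers stand for weaker inhibition and lower numbers for stronger inhibition), compound 1 `CC/C(=C(/c1ccc(/C=C/C(=O)O)cc1)c1ccc2[nH]ncc2c1)c1ccccc1C` gives 4 nM. Among the compounds with values here, compound 2 `CC/C(=C(/c1ccc(/C=C/C(=O)O)cc1)c1ccc2[nH]ncc2c1)c1ccncc1Cl` gives 4 nM, so it stands level with compound 1 on the numbers so far. These two compounds differ only in the aromatic ring on a double-bonded chain carbon bound to a double-bonded chain carbon and a saturated chain carbon, where 3-chloropyridin-4-yl takes the place of 2-methylphenyl. Within the data shown here, that exchange is the only measured step, and it is small: no change at the digits printed from compound 1 to compound 2 (within the scatter).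

Compound 3 `CC/C(=C(/c1ccc(/C=C/C(=O)O)cc1)c1ccc2[nH]ncc2c1)c1cscc1C` has not yet been measured. It changes the same place again, with 4-methylthiophen-3-yl in place of 3-chloropyridin-4-yl on a double-bonded chain carbon bound to a double-bonded chain carbon and a saturated chain carbon. Among the measured compounds shown here, a five-membered ring now stands where both measured compounds carry a six-membered one, and no measured compound shows what that does. The expectation therefore rests on one step at this place, no change at the digits printed from compound 1 to compound 2 (within the scatter), which is thin evidence. No change beyond the scatter is expected, and no direction can be favoured. The expected step is no change at the digits printed from compound 2 to compound 3 (within the scatter). For compound 3 the estimated value is 4 nM, with an expected range from 1.5 nM to 11 nM.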

Compound 3, half-maximal inhibitory concentration: 2 nM
The estimate for compound 3 lay 2.0-fold (0.30 log units) above the measured number; the range from low to high includes it.
By their numbers in this assay, from the lowest: compounds 3, 1 and 2 (each within the scatter of the next).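

In this assay a five-membered ring serves at this place as well as a six-membered one: 4-methylthiophen-3-yl gives a 2.0-fold lower number from compound 2 to compound 3 (0.30 log units; within the scatter) and, set against 2-methylphenyl, a 2.0-fold lower number from compound 1 to compound 3 (0.30 log units; within the scatter) in the same comparison. The place, on a double-bonded chain carbon bound to a double-bonded chain carbon and a saturated chain carbon, has now held a ring of carbon only, one with nitrogen and one with sulfur, and all three compounds stay within the scatter of one another, so neither ring size nor the hetero atom makes a readable difference among them. Nothing available explains why these numbers stay so close.

On these data alone, all three rings carry a methyl or a chlorine, so it remains open whether a plain phenyl, with neither group, or a saturated ring such as cyclohexyl would hold up as well at this place. The rest of the structure is the same in all three compounds, which also leaves open how a propyl chain would read in place of the ethyl chain.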